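This account rests on a few compounds, and the source may have more. Where it says the series, first, only, none or still open, it means among the compounds named here.

Measured in a functional assay on BGC-823 cells (Homo sapiens) for cytotoxicity, read by MTT assay, with a stated time of 48 h; on this read-out lower numbers stand for stronger inhibition and higher numbers for weaker inhibition:
- compound 1 `O=C(CSc1nnc(-c2ccncc2)o1)N/N=C/c1ccc([N+](=O)[O-])cc1`: 31500 nM
- compound 2 `COc1ccc(/C=N/NC(=O)CSc2nnc(-c3ccncc3)o2)cc1`: 19800 nM

Going by the values given here, compound 1 holds one of only two numbers so far, and compound 2 lies within the scatter of it, so neither ranks ahead. Compound 3 `O=C(CSc1nnc(-c2ccncc2)o1)N/N=C/c1cccc(F)c1` is still unmeasured. It carries 3-fluorophenyl in place of 4-nitrophenyl on a carbon with a double bond to nitrogen. Among the compounds with values here, the one measured step that also gives up the nitro group puts methoxy in place of nitro on an aromatic carbon. On the strength of a 1.6-fold lower number from compound 1 to compound 2 (0.20 log units; within the scatter) alone, no step beyond the scatter is expected in this assay. The expected step is a 1.3-fold lower number from compound 1 to compound 3 (0.10 log units; within the scatter). For compound 3 the estimate is 25000 nM, with an expected range of 11000 nM to 55000 nM.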

Compound 3, half-maximal inhibitory concentration: 27500 nM
Estimate against measurement, compound 3: 1.1-fold (0.04 log units) below, and the stated range covers the measured number.
By their numbers in this assay, from the lowest: compounds 2, 3 and 1 (each within the scatter of the next).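

In this assay, replacing 4-nitrophenyl with 3-fluorophenyl gives a 1.1-fold lower number from compound 1 to compound 3 (0.06 log units; within the scatter), and replacing 4-methoxyphenyl with 3-fluorophenyl gives a 1.4-fold higher number from compound 2 to compound 3 (0.14 log units; within the scatter). Both steps lie within the scatter, so a third substituted phenyl group, carrying fluorine at a different ring position, still cannot be told apart from the first two at this place.

From the compounds shown here alone, whether a ring bearing an amine or a carboxylic acid, or a longer chain in place of the ring, would move the number beyond the scatter remains open. No other measurement here helps to interpret these numbers.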